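The source may report more compounds than this note shows. Statements on the series, on what has been measured and on what is new or still open speak of the compounds shown alone.

Measured compounds:
compound 1 `CNc1ncnc2c1c(-c1ccsc1)cn2[C@@H]1O[C@H](CO)[C@@H](O)[C@H]1O` – > 100000 nM
compound 2 `O=c1[nH]cnc2c1c(-c1ccsc1)cn2[C@@H]1O[C@H](CO)[C@@H](O)[C@H]1O` – > 100000 nM
compound 3 `O=c1[nH]cnc2c1c(-c1cccs1)cn2[C@@H]1O[C@H](CO)[C@@H](O)[C@H]1O` – > 100000 nM

In an ADME assay on MRC5 cells (Homo sapiens), read by MTT assay, with a stated time of 72 h (on this read-out lower numbers stand for stronger inhibition and higher numbers for weaker inhibition), compound 1 gives only a limit, > 100000 nM. Compound 2 likewise stops at a limit, > 100000 nM. Compound 3 also reports a limit, > 100000 nM. Within the data shown here, all three values sit at the limit of > 100000 nM in this assay, at which 3 of the 3 values shown sit, so no compound stands apart from another on this read-out.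

Compound 4 `CNc1ncnc2c1c(-c1cccs1)cn2[C@@H]1O[C@H](CO)[C@@H](O)[C@H]1O` is the unmeasured partner of compound 1; the two differ by thiophen-2-yl in place of thiophen-3-yl on an aromatic carbon. Among the measured compounds shown here, the only measured step of the same kind is a step that the two limits leave unreadable from compound 2 to compound 3, which the two limits leave unreadable in size and direction. No readable movement beyond the scatter is therefore expected for the corresponding step in this assay.

Compound 4 is expected to give 200000 nM, in the range 60000 nM to 1000000 nM, most likely again as a limit. The expected step that the limit leaves unreadable from compound 1 to compound 4 is an estimate with no measured support beyond the limits.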

Compound 4, half-maximal inhibitory concentration: > 100000 nM
Compound 4: a limit, no number; the forecaster's own chance of this, stated with the estimate: 85%; the middle value does not contradict the limit.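

No step from compound 1 to compound 4 can be read in this assay, since both stop at a limit: the limit of > 100000 nM in this assay, at which 4 of the 4 values shown sit.

The compounds shown leave open whether thiophen-2-yl and thiophen-3-yl differ at all on this read-out.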